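Spirocyclic amide series: cyclic amine variant of compound 3

The source may report more compounds than this note shows. Statements on the series, on what has been measured and on what is new or still open speak of the compounds shown alone.

Of the compounds shown here, three of the shared core have been measured in an assay on HEK293 cells for displacement of a labelled ligand from NPC1-like intracellular cholesterol transporter 1 (Homo sapiens); on this read-out higher numbers stand for weaker inhibition and lower numbers for stronger inhibition. Compound 3 `CC(C)(C)c1ccc(C(=O)N2CCC3(CC2)C(=O)N(CC(=O)NCCCNS(C)(=O)=O)CN3c2ccccc2)cc1` gives 10400 nM; this is the second highest number of the three. Compound 1 `CC(C)(C)c1ccc(C(=O)N2CCC3(CC2)C(=O)N(CC(=O)NCCCCCNS(C)(=O)=O)CN3c2ccccc2)cc1` gives 5500 nM, close to compound 3: a 1.9-fold higher number from compound 1 to compound 3 (0.28 log units; within the scatter). Compound 2 `CC(C)(C)c1ccc(C(=O)N2CCC3(CC2)C(=O)N(CC(=O)N2CCNCC2)CN3c2ccccc2)cc1` gives 22000 nM, the highest number of the set, with a 4.0-fold higher number from compound 1 to compound 2 (0.60 log units; beyond the scatter) and a 2.1-fold lower number from compound 2 to compound 3 (0.33 log units; beyond the scatter).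

Compound 4 `CCOC(=O)C1CCCN(C(=O)CN2CN(c3ccccc3)C3(CCN(C(=O)c4ccc(C(C)(C)C)cc4)CC3)C2=O)C1` has not yet been measured. The change from compound 3 is 3-(ethoxycarbonyl)piperidin-1-yl in place of (3-(methanesulfonamido)propyl)amino on a carbonyl carbon. The two steps that bear on it are those that exchange an open chain bearing the methanesulfonamido group for a cyclic amine on the same carbonyl carbon, namely a 4.0-fold higher number from compound 1 to compound 2 (0.60 log units; beyond the scatter) and a 2.1-fold lower number from compound 2 to compound 3 (0.33 log units; beyond the scatter). Both show the open chains giving the lower numbers and the cyclic amine the higher one, and both are modest. The entering group in compound 4 is again a cyclic amine, though one bearing an ethoxycarbonyl and not a ring nitrogen with a hydrogen.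

For compound 4 in this assay a modest move to a higher number is therefore expected, of about a 1.5-fold higher number from compound 3 to compound 4 (0.19 log units; within the scatter), because compound 2 gave 22000 nM. Compound 4 is estimated at 16000 nM, with a range from 6000 nM to 45000 nM.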

Compound 4, half-maximal inhibitory concentration: 8200 nM
For compound 4 the middle estimate is 2.0-fold (0.29 log units) above the measured one, within the range that was stated.
By their numbers in this assay, from the lowest: compounds 1, 4 and 3 (each within the scatter of the next); then compound 2.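

In this assay a cyclic amine on this carbonyl carbon does not by itself give a number as high as that of compound 2: 3-(ethoxycarbonyl)piperidin-1-yl in place of piperazin-1-yl gives (a 2.7-fold lower number from compound 2 to compound 4 (0.43 log units; beyond the scatter)), a modest step beyond the scatter. The same group also stands level with both open chains bearing the methanesulfonamido group (a 1.3-fold lower number from compound 3 to compound 4 (0.10 log units; within the scatter)) and (a 1.5-fold higher number from compound 1 to compound 4 (0.17 log units; within the scatter)), with both steps within the scatter, so at this position neither that chain nor the hydrogen-bond donors it carries are needed to reach this range of numbers, and among the four compounds only compound 2 stands apart. No measurement shown gives a reason for these differences.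

Going by these compounds, it remains open whether the ethoxycarbonyl or the piperidine ring accounts for the gap to compound 2, a question that plain piperidin-1-yl and the corresponding carboxylic acid would address. On these data alone, it is also open whether the free ring amine of the piperazin-1-yl group matters, which an N-acetylpiperazin-1-yl group or a morpholin-4-yl group would test.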